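Moving two fluorines around a benzyl ether ring

The compounds below may be only part of what the source reports. "The series", "measured", "known", "first", "only" and "open" are said of these compounds alone.

Measured so far in an assay on CHO cells for binding affinity to metabotropic glutamate receptor 2 (Rattus norvegicus); a lower number here means a stronger inhibitor, a higher number a weaker inhibitor:
Compound 1, `CO[C@@H]1C[C@@H]2[C@H]([C@]1(N)C(=O)O)[C@@]2(F)C(=O)O`, gives 39.2 nM.
Compound 2, `N[C@]1(C(=O)O)[C@H]2[C@@H](C[C@H]1OCc1ccc(F)c(F)c1)[C@]2(F)C(=O)O`, gives 2.27 nM.

Compound 2 holds the lowest of the two numbers in this assay; the nearest is compound 1, with a higher number. Within the data shown here, the only step seen so far, a 17-fold lower number from compound 1 to compound 2 (1.24 log units; beyond the scatter), came from placing a 3,4-difluorophenyl where before there was hydrogen. Compound 3, `N[C@]1(C(=O)O)[C@H]2[C@@H](C[C@H]1OCc1cccc(F)c1F)[C@]2(F)C(=O)O`, keeps every atom of compound 2 but joins them differently: 2,3-difluorophenyl in place of 3,4-difluorophenyl on a saturated chain carbon bound to an oxygen on a saturated carbon. Among the measured compounds shown here, no measured step shows what shifting the two fluorines around the ring does; the step from compound 1 to compound 2 shows only that the difluorophenyl group as a whole is worth a large gain. With the group kept and only its fluorine pattern changed, the step expected in this assay stays within the scatter, leaning if anything toward a higher number, a 1.5-fold higher number from compound 2 to compound 3 (0.19 log units; within the scatter). Compound 3 is therefore estimated at 3.5 nM, in the range 1.2 nM to 10 nM.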

Compound 3, inhibition constant: 4.25 nM
Estimate against measurement, compound 3: 1.2-fold (0.08 log units) below; low and high end bracket the measured number.
By their numbers in this assay, from the lowest: compounds 2 and 3 (each within the scatter of the next); then compound 1.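

Moving the fluorines from the 3,4-difluorophenyl to the 2,3-difluorophenyl pattern gives a 1.9-fold higher number from compound 2 to compound 3 (0.27 log units; within the scatter) in this assay so at this position the two patterns cannot be told apart. The gain over compound 1 remains with the new pattern, shown by a 9.2-fold lower number from compound 1 to compound 3 (0.96 log units; beyond the scatter) so that gain does not depend on the exact fluorine pattern of compound 2. No measurement at hand explains why the two patterns read alike.

From the compounds shown here alone, two fluorine patterns are only a small sample, so it stays open whether the gain needs fluorine on the ring at all, which a plain phenyl, a chlorophenyl or a methoxyphenyl group in the same place would test. Also open, going by these compounds, is whether a phenethyl ether, with its longer chain, would keep the gain.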